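This account rests on a few compounds, and the source may have more. Where it says the series, first, only, none or still open, it means among the compounds named here.

Working notes on the series. Among the compounds with values here, compound 1 `CC(C(=O)NCc1ccc(C(F)(F)F)nc1N(C)C)c1ccc(NS(C)(=O)=O)c(F)c1` gives 19.1 nM in a functional assay on CHO-K1 cells for antagonist activity at transient receptor potential cation channel subfamily V member 1 (Homo sapiens), read by FLIPR (on this read-out higher numbers stand for weaker inhibition and lower numbers for stronger inhibition), the lowest of the two numbers measured so far. Compound 2 `C[C@H](C(=O)NCc1ccc(C(F)(F)F)nc1N1CC[C@@H](N(C)C)C1)c1ccc(NS(C)(=O)=O)c(F)c1` gives 101 nM in this assay, and the gap to compound 1 lies beyond the scatter. Compound 3 `CC(C(=O)NCc1ccc(C(F)(F)F)nc1N1CCC(C(F)(F)F)CC1)c1ccc(NS(C)(=O)=O)c(F)c1` is not yet measured; it differs from compound 1 by 4-(trifluoromethyl)piperidin-1-yl in place of dimethylamino on an aromatic carbon. Within the data shown here, no step between measured compounds covers this exact change, and the only guide is that compound 2 sits at 101 nM with a larger ring in place of dimethylamino. A modest step toward weaker inhibition is expected, a 2.1-fold higher number from compound 1 to compound 3 (0.32 log units; beyond the scatter). Compound 3 is estimated at 40 nM, range 10 nM to 160 nM.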

Compound 3, inhibition constant: 0.6 nM
Compound 3: the middle estimate sits 67-fold (1.82 log units) above what was measured, and the stated range ends above it.
By their numbers in this assay, from the lowest: compound 3; then compound 1; then compound 2.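

In this assay, 4-(trifluoromethyl)piperidin-1-yl in place of dimethylamino gives a 32-fold lower number from compound 1 to compound 3 (1.50 log units; beyond the scatter). Within the data shown here, this shows that the aromatic carbon next to the ring nitrogen can carry a far larger group than dimethylamino, with much stronger inhibition rather than the loss that the earlier compounds left possible. Nothing available explains the size of this step.

Going by these compounds, it remains open whether the gain comes from the piperidine ring or from its trifluoromethyl group. Plain piperidine, 4-methylpiperidine or morpholine at this carbon would help separate these contributions.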